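The source may report more compounds than this note shows. Statements on the series, on what has been measured and on what is new or still open speak of the compounds shown alone.

The measured compounds are compound 1 `COc1cc(C2=NOC(c3c[nH]c4ccccc34)C2)cc(OC)c1OC`, compound 2 `COc1ccc2c(C3CC(c4ccncc4)=NO3)c[nH]c2c1` and compound 3 `c1ccc2c(C3CC(c4ccncc4)=NO3)c[nH]c2c1`.

In a functional assay on CWR22R cells (Homo sapiens) for inhibition, read by MTT assay, with a stated time of 48 h (on this read-out higher numbers stand for weaker inhibition and lower numbers for stronger inhibition), compound 1 gives 4510 nM. In this assay compound 2 gives 16300 nM. For compound 3 the result in this assay is only a limit of the assay, > 100000 nM, which is the reading at the limit of > 100000 nM in this assay, at which 1 of the 3 values shown sits. The core of compound 1 and the core of compound 3 differ in a way that is not broken down here; the two structures stand side by side above.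

Between compound 3 and compound 2 a single change is made: methoxy in place of hydrogen on an aromatic carbon. This change brings an at least 6.1-fold lower number from compound 3 to compound 2 (0.78 log units; beyond the scatter), and its size is bounded because compound 3 sits at the limit of > 100000 nM in this assay, at which 1 of the 3 values shown sits. Compound 1, for its part, gives the lowest of the two numbers in this assay, with compound 2 the nearer of the two.

Compound 4 `COc1ccc2[nH]cc(C3CC(c4cc(OC)c(OC)c(OC)c4)=NO3)c2c1` has not yet been measured in this assay. It arises from compound 1 by the same change that took compound 3 to compound 2: methoxy in place of hydrogen on an aromatic carbon. Beside the earlier step, this one is expected to move the number in the same direction, though more cautiously, since the earlier step rests on a single pair and one of its two ends is a limit. The expected step is a 3.5-fold lower number from compound 1 to compound 4 (0.54 log units; beyond the scatter). On this basis compound 4 is estimated at 1300 nM in this assay, most likely between 400 nM and 4500 nM.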

Compound 4, half-maximal inhibitory concentration: 11300 nM
The estimate for compound 4 lay 8.7-fold (0.94 log units) below the measured number; measured number above the stated range.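

On the core of compound 1, methoxy in place of hydrogen on an aromatic carbon brings a 2.5-fold higher number from compound 1 to compound 4 (0.40 log units; beyond the scatter) in this assay, so the change that lowered the number on the core of compound 3 raises it here. The same change therefore does not carry over from one core to the other in this series, and its direction depends on the core it is made on: the same change on two cores in this assay, an at least 6.1-fold lower number (0.78 log units; beyond the scatter) from compound 3 to compound 2 and a 2.5-fold higher number (0.40 log units; beyond the scatter) from compound 1 to compound 4, at least 15-fold (1.18 log units) apart, beyond the scatter of two such steps Only one pair stands on each core, so this shows neither why the direction differs nor how the change would run on a third core, and the reading for compound 3 is only a limit of the assay: the limit of > 100000 nM in this assay, at which 1 of the 4 values shown sits.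

The compounds shown leave open whether this reversal belongs to methoxy alone, or whether another group on the same aromatic carbon of the core of compound 1, such as a hydroxyl, a fluorine or an amine, would also raise the number. They also leave open how the number would respond to methoxy on the other aromatic carbons of that six-membered ring.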